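Mirror-Image Cyclopropane Amide and Its Expected Response

The source may report more compounds than this note shows. Statements on the series, on what has been measured and on what is new or still open speak of the compounds shown alone.

Compound 1 `CCC(=O)N1CC2CC(C1)N2` was tested in an assay on CHO cells for agonist activity at Neuronal acetylcholine receptor; alpha3/alpha6/beta2/beta3 (Homo sapiens), read by FLIPR and calcium flux; a higher number here means a larger maximal response, a lower number a smaller maximal response; in this assay compound 1 gives 120%. Compound 2 `C[C@@H]1C[C@@H]1C(=O)N1CC2CC(C1)N2` gives 87%, the lower of the two numbers measured, and the step of a number 33 percentage points lower from compound 1 to compound 2 (beyond the scatter) is a large fall. Compound 3 `C[C@H]1C[C@H]1C(=O)N1CC2CC(C1)N2` has the same atoms and bonds as compound 2 and differs only in configuration: the two compounds have the same atoms and bonds; at least one stereo element is drawn with a configuration in one of them and without one in the other: 2 of 4 stereo elements differ; a stereocentre at a saturated ring carbon is drawn R in compound 2 and S in compound 3; a stereocentre at a saturated ring carbon is drawn S in compound 2 and R in compound 3. Among the compounds with values here, the single measured step concerns a chain replaced by a ring, not a change of configuration, so it gives no direction here. Compound 3 is therefore expected to stay close to compound 2, with an estimated step of a number 3 percentage points higher from compound 2 to compound 3 (within the scatter), an estimate of 90%, within a range from 50% to 130%.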

Compound 3, largest response reached (Emax), in percent of the reference or control that the assay uses: 60%
Beside the measured number, compound 3's estimate is 30 percentage points above it, within the range that was stated.
By their numbers in this assay, from the lowest: compound 3; then compound 2; then compound 1.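

In this assay, configuration alone changes the response, with no atom or bond altered: the result is a number 27 percentage points lower from compound 2 to compound 3 (beyond the scatter). The effect of putting 2-methylcyclopropyl in place of ethyl therefore depends on how the ring is drawn, and here the result is a number 60 percentage points lower from compound 1 to compound 3 (beyond the scatter). One caution applies to reading the first step as a clean comparison of two configurations: the fact that one of compounds 2 and 3 is drawn with a defined configuration and the other without, at the place where they differ. Still open, from the compounds shown here alone, is whether an ethyl group or a hydroxyl group in place of the methyl on the cyclopropane ring would show the same dependence on configuration.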